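The source may hold more compounds than are shown below. What is called first, only, known or untested is meant among the compounds shown, and "the series" means these compounds.

In a functional assay on RS4-11 cells (Homo sapiens) for inhibition, read by CCK-8 assay, with a stated time of 48 h, tested at 20 uM (on this read-out lower numbers stand for less inhibition of growth and higher numbers for more inhibition of growth at the one concentration tested), compound 1 (`COc1ccc(S(=O)(=O)Oc2ccccc2/C=C(\C#N)C(=O)Nc2nnc(Cc3ccc(F)cc3)s2)cc1`) gives 76% and compound 2 (`N#C/C(=C\c1ccccc1OS(=O)(=O)c1ccc(F)cc1)C(=O)Nc1nnc(Cc2ccc(F)cc2)s1`) gives 59% as the lower of the two numbers. Compound 3 (`N#C/C(=C\c1ccccc1OS(=O)(=O)c1ccc(F)cc1)C(=O)Nc1nnc(Cc2ccc(Cl)cc2)s1`) departs from compound 2 by chloro in place of fluoro on an aromatic carbon in a change from 4-fluorobenzyl to 4-chlorobenzyl. Among the measured compounds shown here, the only measured step, a number 17 percentage points lower from compound 1 to compound 2 (beyond the scatter), is a different exchange, fluoro in place of methoxy, and leaves the 4-fluorobenzyl group untouched. No measurement therefore bears directly on this change. The expected step is a number 2 percentage points higher from compound 2 to compound 3 (within the scatter) and none beyond the scatter is expected in this assay in either direction. Compound 3 is estimated at 61% with an expected range of 45% to 77% in this reading.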

Compound 3, percent growth inhibition at one concentration: 64%
Beside the measured number, compound 3's estimate is 3 percentage points below it; the range from low to high includes it.
By their numbers in this assay, from the lowest: compounds 2 and 3 (each within the scatter of the next); then compound 1.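

In this assay, among the compounds shown here, the change from 4-fluorobenzyl to 4-chlorobenzyl gives a number 5 percentage points higher from compound 2 to compound 3 (within the scatter) and is the first reading at this position, which compound 1 and compound 2 both hold as 4-fluorobenzyl. At this position, the assay does not tell chloro from fluoro. Nothing measured here offers a reason for this result.

From the compounds shown here alone, whether an amine, a carboxylic acid or a longer chain at this place would read differently stays open. So does whether chloro would give a similar step alongside the methoxy group of compound 1.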